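A few compounds are considered here, and "the series" means these few. Any claim that something is new, unique, unknown or untested is made for them only; others in the source may bear on it.

Measured in a functional assay (aorta) with Rattus norvegicus as the target; on this read-out lower numbers stand for an effect already at smaller amounts and higher numbers for an effect only at larger amounts of compound:
- compound 1 `CNC(=O)C1=CC(C)(C(F)(F)F)Oc2ccc([N+](=O)[O-])cc21`: 2.69 nM
- compound 2 `CC1(C)C=C(/C(S)=N\CCC#N)c2cc([N+](=O)[O-])ccc2O1`: 0.372 nM
- compound 3 `CC1(CF)C=C(/C(S)=N\CCC#N)c2cc([N+](=O)[O-])ccc2O1`: 1.86 nM

Compound 3 lies within the usual scatter of compound 1, and its number is clearly higher than that of compound 2. The next compound to be tested is compound 4 `CC1(C(F)(F)F)C=C(/C(S)=N\CCC#N)c2cc([N+](=O)[O-])ccc2O1`. It has trifluoromethyl in place of fluoromethyl on a saturated ring carbon.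

Among the measured compounds shown here, one measured step bears directly on this change: a 5.0-fold higher number from compound 2 to compound 3 (0.70 log units; beyond the scatter). There, fluoro replaced hydrogen on a saturated chain carbon, and the number rose. A single step makes no trend, but it points towards higher numbers as more fluorine is added. A second hint tempers how far that might go: compound 1 also carries trifluoromethyl, although it differs elsewhere, and it gives 2.69 nM.

A small further rise in this assay is therefore expected, one that may not clear the scatter. The expected step is a 1.6-fold higher number from compound 3 to compound 4 (0.21 log units; within the scatter). The estimate for compound 4 is 3 nM, with an expected range from 0.6 nM to 15 nM.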

Compound 4, half-maximal effective concentration: 0.363 nM
Compound 4: middle estimate off by 8.3-fold (0.92 log units), on the high side, outside the stated range (below it).
By their numbers in this assay, from the lowest: compounds 4 and 2 (each within the scatter of the next); then compounds 3 and 1 (each within the scatter of the next).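

In this assay added fluorine at this saturated ring carbon does not push the number one way: after a 5.0-fold higher number from compound 2 to compound 3 (0.70 log units; beyond the scatter) comes a 5.1-fold lower number from compound 3 to compound 4 (0.71 log units; beyond the scatter) with trifluoromethyl in place of fluoromethyl. Methyl and trifluoromethyl cannot be told apart here, with a 1.0-fold lower number from compound 2 to compound 4 (0.01 log units; within the scatter) and that step lying within the scatter, so compound 3 with its fluoromethyl is the one that stands apart among these three. With trifluoromethyl kept in place, the group of 7 heavy atoms on the double-bonded ring carbon gives a 7.4-fold lower number from compound 1 to compound 4 (0.87 log units; beyond the scatter) and so shows that the number of compound 1 says little about trifluoromethyl itself, while no evidence accompanies these numbers to account for any of these steps.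

Still open, on these data alone, is where difluoromethyl would fall on this ring carbon. Also open, as far as these compounds go, is whether an ethyl group or a longer chain there would match methyl and trifluoromethyl.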